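The source may hold more compounds than are shown below. What is called first, only, known or untested is meant among the compounds shown, and "the series" means these compounds.

Measured so far:
compound 1, `O=C(CCCCCCNC(=O)C(O)(O)C(F)(F)F)Nc1ccccc1Br` — 14500 nM
compound 2, `OC(O)(c1c(F)c(F)c(-n2cc(-c3ccccc3)nn2)c(F)c1F)C(F)(F)F` — > 100000 nM

Within the data shown here, in a functional assay on HCT-116 cells (Homo sapiens) for inhibition, read by colorimetric assay, with a stated time of 3 days (a higher number here means a weaker inhibitor, a lower number a stronger inhibitor), compound 1 gives 14500 nM, the only numerical value in the set. Compound 2 gives > 100000 nM, which is a limit of the assay and not a number. One of the two values shown sits at this limit (the limit of > 100000 nM in this assay, at which 1 of the 2 values shown sits). Compound 1 is therefore the single measured point from which the next compound is read.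

Compound 3, `O=C(CCCCCCNC(=O)C(O)(O)C(F)(F)F)Nc1nccs1`, keeps the chain and the hydrated trifluoromethyl end of compound 1 and differs only at the amide-type nitrogen: 1,3-thiazol-2-yl in place of 2-bromophenyl on an amide-type nitrogen. Among the measured compounds shown here, no pair of measured compounds differing in one place is available, so the size of such a step has no precedent in this set. The change trades a six-membered aromatic ring of carbon only for a five-membered aromatic ring with two hetero atoms at the same anchor. The expected step of a 1.5-fold higher number from compound 1 to compound 3 (0.18 log units; within the scatter) is modest, towards weaker inhibition if anything, and may well stay within the scatter of repeated measurements. Compound 3 is estimated at 22000 nM, with a range from 6000 nM to 80000 nM.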

Compound 3, half-maximal inhibitory concentration: 10800 nM
The estimate for compound 3 lay 2.0-fold (0.31 log units) above the measured number, within the range that was stated.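

In this assay, the first step read at this position is a 1.3-fold lower number from compound 1 to compound 3 (0.13 log units; within the scatter): replacing 2-bromophenyl with 1,3-thiazol-2-yl on an amide-type nitrogen leaves the two compounds indistinguishable. At this anchor, therefore, a six-membered aromatic ring of carbon only and a five-membered aromatic ring with 2 hetero atoms give values that cannot be told apart, even though the bromine leaves and 2 hydrogen-bond acceptors enter. Nothing shown gives a cause for this step, and the single limit in the set belongs to a compound that differs in more than one place.

The compounds shown leave open whether any group on this nitrogen can move the value beyond the scatter, for example a ring carrying an amine or a carboxylic acid, or an unsubstituted phenyl that would separate the effect of the bromine from that of the ring. The linker and the hydrated trifluoromethyl end are also untested by any step, so a longer chain, or a hydroxamic acid in place of that end, remains an open question for the series.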